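Swapping an ethyl for an acetyl on the aromatic ring

The compounds below may be only part of what the source reports. "The series", "measured", "known", "first", "only" and "open" are said of these compounds alone.

Of the compounds shown here, three sharing one core have been measured in a functional assay on CHO cells for agonist activity at Alpha-2B adrenergic receptor (Homo sapiens); on this read-out higher numbers stand for an effect only at larger amounts of compound and lower numbers for an effect already at smaller amounts. Compound 1 `CCc1ccccc1OC(C)C1=NCCN1` gives 10000 nM, which places it second highest of the three numbers. Its closest neighbour is compound 3 `CC(Oc1ccccc1OC1CC1)C1=NCCN1`, which gives 12900 nM; the step of a 1.3-fold higher number from compound 1 to compound 3 (0.11 log units; within the scatter) stays within the scatter. Compound 2 `CCOc1ccccc1OC(C)C1=NCCN1` gives 3160 nM, and the step of a 3.2-fold lower number from compound 1 to compound 2 (0.50 log units; beyond the scatter) is a modest one beyond the scatter.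

The next compound, compound 4 `CC(=O)c1ccccc1OC(C)C1=NCCN1`, is not yet measured. It differs from compound 1 in one place: acetyl in place of ethyl on an aromatic carbon. The two measured steps that start from compound 1 both exchange the ethyl for a group carrying one hydrogen-bond acceptor, as the acetyl does. One of them, a 3.2-fold lower number from compound 1 to compound 2 (0.50 log units; beyond the scatter), lowered the number modestly; the other, a 1.3-fold higher number from compound 1 to compound 3 (0.11 log units; within the scatter), stayed within the scatter. On that basis a small step downward, or none beyond the scatter, is expected, as a 1.7-fold lower number from compound 1 to compound 4 (0.22 log units; within the scatter). Compound 4 is therefore estimated at 6000 nM, with a range from 2000 nM to 20000 nM.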

Compound 4, half-maximal effective concentration: 295 nM
Estimate against measurement, compound 4: 20-fold (1.31 log units) above; the measured number lies below the stated range.
By their numbers in this assay, from the lowest: compound 4; then compound 2; then compounds 1 and 3 (each within the scatter of the next).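

At this place on the aromatic ring, the acetyl of compound 4 stands well apart from all three other groups in this assay: a 34-fold lower number from compound 1 to compound 4 (1.53 log units; beyond the scatter), a 44-fold lower number from compound 3 to compound 4 (1.64 log units; beyond the scatter) and an 11-fold lower number from compound 2 to compound 4 (1.03 log units; beyond the scatter), all large steps, whereas the earlier groups differed only modestly or within the scatter. The ethoxy of compound 2 and the cyclopropyloxy of compound 3 also carry a hydrogen-bond acceptor, so the presence of an acceptor at this place is not enough on its own to give a drop of this size. Nothing available here explains why the acetyl differs so strongly from these groups.

From the compounds shown here alone, it remains open whether the gain belongs to the carbonyl itself or to the acetyl group as a whole. A propanoyl, a primary amide or a methyl ester at the same place would help to separate these two readings.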